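This account rests on a few compounds, and the source may have more. Where it says the series, first, only, none or still open, it means among the compounds named here.

Compound 2 `Cc1nc(N)nc(N[C@@H]2C[C@H](CO)[C@@H](O)[C@H]2O)c1-c1nc2ccccc2s1` gives the lowest of the two numbers in an ADME assay on cells (Homo sapiens) for cytotoxicity, read by polymerase chain reaction, with a stated time of 3 days; on this read-out lower numbers stand for higher toxicity in this test and higher numbers for lower toxicity in this test: in this assay compound 2 gives 4000 nM, whereas compound 1 `Nc1nc(Cl)c(-c2nc3ccccc3o2)c(N[C@@H]2C[C@H](CO)[C@@H](O)[C@H]2O)n1` gives 12000 nM, a gap beyond the scatter. Compound 3 `Cc1nc(Nc2ncco2)nc(N[C@@H]2C[C@H](CO)[C@@H](O)[C@H]2O)c1-c1nc2ccccc2s1` has not yet been measured in this assay. It differs from compound 2 by 1,3-oxazol-2-yl in place of hydrogen on a nitrogen on an aromatic ring. Among the measured compounds shown here, no step between measured compounds isolates this change, so the step expected is no change at the digits printed from compound 2 to compound 3 (within the scatter), that is, none beyond the scatter. On that basis compound 3 is estimated at 4000 nM in this assay, with a range from 1300 nM to 12000 nM.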

Compound 3, half-maximal cytotoxic concentration: > 25000 nM
Compound 3 was reported as a limit; the forecaster's own chance of this, stated with the estimate: 10%; middle value at least 6.2-fold (0.79 log units) from the limit.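

Compounds 1 and 2 both carry the plain amino group, so neither says anything about substitution on this nitrogen. Replacing its hydrogen with 1,3-oxazol-2-yl gives, in this assay, an at least 6.2-fold higher number from compound 2 to compound 3 (0.79 log units; beyond the scatter), so this position accepts a five-membered aromatic ring without a lower number. Compound 3 stands at a limit of the assay, not a number, so the full size of the step stays unread: the limit of > 25000 nM in this assay, at which 1 of the 3 values shown sits.

Open, as far as these compounds go, is whether the shift belongs to this ring specifically or to any group on this nitrogen, such as a methyl or a phenyl. Also open, from the compounds shown here alone, is whether the same change carries over to the core of compound 1.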